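Swapping a Para Substituent on the Anilide: Methoxy to Chloro

The compounds below may be only part of what the source reports. "The series", "measured", "known", "first", "only" and "open" are said of these compounds alone.

Measured so far:
- compound 1 `Cc1cccc(C)c1NC(=O)/C=C/C(=O)N1C/C(=C\c2ccc([N+](=O)[O-])cc2)C(=O)/C(=C/c2ccc([N+](=O)[O-])cc2)C1`, 210 nM
- compound 2 `CC(=O)c1ccc(NC(=O)/C=C/C(=O)N2C/C(=C\c3ccccc3)C(=O)/C(=C/c3ccccc3)C2)cc1`, 1400 nM
- compound 3 `COc1ccc(NC(=O)/C=C/C(=O)N2C/C(=C\c3ccccc3)C(=O)/C(=C/c3ccccc3)C2)cc1`, 1100 nM

All three were tested in a functional assay on Molt4/C8 cells (Homo sapiens) for cytotoxicity; a higher number here means a weaker inhibitor, a lower number a stronger inhibitor. Compound 3 stands second highest of the three numbers. Its nearest neighbour is compound 2, whose number is higher by a margin within the scatter; compound 1 is furthest, with a number lower by a margin beyond the scatter. Among the measured compounds shown here, the one step measured between single-point neighbours, a 1.3-fold lower number from compound 2 to compound 3 (0.10 log units; within the scatter), lies within the scatter.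

Compound 4 `O=C(/C=C/C(=O)N1C/C(=C\c2ccccc2)C(=O)/C(=C/c2ccccc2)C1)Nc1ccc(Cl)cc1` has not yet been measured. It differs from compound 3 by chloro in place of methoxy on an aromatic carbon, on an aromatic carbon of a six-membered ring of carbon only, para to a large group. For the measured compounds named here, no measured step shows chloro in place of methoxy, or chloro at all, at this place; the only step at this place, from acetyl to methoxy, was within the scatter. Going by the values given here, with that as the sole guide, compound 4 is expected to give 1000 nM (range 400 nM to 2500 nM), and the expected step of a 1.1-fold lower number from compound 3 to compound 4 (0.04 log units; within the scatter) is estimated to stay within the scatter.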

Compound 4, half-maximal inhibitory concentration: 1800 nM
Beside the measured number, compound 4's estimate is 1.8-fold (0.26 log units) below it; low and high end bracket the measured number.
By their numbers in this assay, from the lowest: compound 1; then compounds 3, 2 and 4 (each within the scatter of the next).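

In this assay, the step of a 1.6-fold higher number from compound 3 to compound 4 (0.21 log units; within the scatter) and the step of a 1.3-fold higher number from compound 2 to compound 4 (0.11 log units; within the scatter) both lie within the scatter, so chloro joins methoxy and acetyl as a third group that cannot be told apart at this place on the anilide ring. Among the compounds shown here, this is the first change here to a single chlorine atom: methoxy leaves with its hydrogen-bond acceptor and chloro brings none, yet the two numbers stay within the scatter of each other. Nothing measured here offers an explanation for these close readings.

Going by these compounds, whether an amine, a carboxylic acid or a longer chain at this place would give a step beyond the scatter remains open. Compound 1 differs from these compounds in more than one place, so its number cannot be tied to any single change.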